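This account rests on a few compounds, and the source may have more. Where it says the series, first, only, none or still open, it means among the compounds named here.

Measured so far in a functional assay on MCF7 cells (Homo sapiens) for inhibition, read by MTT assay, with a stated time of 48 h, tested at 10 uM; a higher number here means more inhibition of growth at the concentration tested, a lower number less inhibition of growth:
Compound 1 `Cc1cc(=O)c2c(O)c(CN3CCC(N4CCCCC4)CC3)c(O)c([C@H]3CCN(C)C[C@H]3O)c2o1`: 25%
Compound 2 `Cc1oc2c([C@H]3CCN(C)C[C@H]3O)c(O)cc(O)c2c(=O)c1C(O)c1ccc(Cl)cc1`: 6%

Compound 2 stands at the lower of the two numbers, and the gap up to compound 1 lies beyond the usual scatter. These two compounds differ in more than one place, so their values show only that gap. Compound 3 `COc1ccc(C(O)c2c(C)oc3c([C@H]4CCN(C)C[C@H]4O)c(O)cc(O)c3c2=O)cc1Br` has not yet been measured. It keeps the core of compound 2 but carries 3-bromo-4-methoxyphenyl in place of 4-chlorophenyl on a saturated chain carbon bound to an aromatic carbon and an oxygen on a saturated carbon. Among the compounds with values here, no measured pair shows the effect of such a swap in this assay, so the expectation starts from compound 2 at 6% and foresees no step beyond the scatter, in either direction. The expected change is a number 3 percentage points higher from compound 2 to compound 3 (within the scatter). For compound 3 the estimated value is 9%, within an expected range from 0% to 22%.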

Compound 3, percent growth inhibition at one concentration: 41%
Compound 3: the middle estimate sits 32 percentage points below what was measured; measured number above the stated range.
By their numbers in this assay, from the lowest: compound 2; then compound 1; then compound 3.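

In this assay the saturated chain carbon bound to an aromatic carbon and an oxygen on a saturated carbon turns out to be a place where the aryl group matters: 3-bromo-4-methoxyphenyl in place of 4-chlorophenyl gives a number 35 percentage points higher from compound 2 to compound 3 (beyond the scatter) and lies beyond the scatter. The earlier pair, compound 1 and compound 2, differed in more than one place and could show nothing about this position alone. Nothing at hand accounts for the size of this step.

Going by these compounds, the entering group differs from the leaving one in more than one respect, so it remains open whether the bromine or the methoxy group carries the step, which 3-bromophenyl and 4-methoxyphenyl could separate. Also open, on these data alone, is how a pyridyl ring or an aminophenyl group would read at this same carbon.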